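The source may report more compounds than this note shows. Statements on the series, on what has been measured and on what is new or still open speak of the compounds shown alone.

Measured so far in a functional assay on NCI-H460 cells (Homo sapiens) for cytotoxicity, read by MTT assay, with a stated time of 72 h (a lower number here means a stronger inhibitor, a higher number a weaker inhibitor), are these values:
compound 1 `CCCCNC1=CC(=O)C=C(C(C)(C)C)C1=O` gives 14000 nM
compound 2 `CC1=CCC[C@H]2[C@](C)(CC3=CC(=O)C=CC3=O)[C@@H](C)CC[C@]12C` gives 84000 nM
compound 3 `CC(C)(C)C1=CC(=O)C=C(NCc2ccccc2)C1=O` gives 14000 nM

Compound 1 stands level with compound 3, and the two share the lowest number of the three, while compound 2 sits higher, beyond the scatter. The next comparison removes the whole amine side chain. Compound 4 `CC(C)(C)C1=CC(=O)C=CC1=O` has hydrogen in place of butylamino on a double-bonded ring carbon and keeps the tert-butyl group.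

Going by the values given here, the only matched step available is no change at the digits printed from compound 1 to compound 3 (within the scatter) and it alters the end of the chain while the amine nitrogen stays in place, so it says little about losing the whole substituent. Compound 2 also carries no amino group, but it differs from compound 1 in much else, so compound 2 at 84000 nM is only a weak guide. On these data alone, with so little evidence, no step beyond the scatter is expected in this assay and the direction stays open. The estimated step is a 1.2-fold lower number from compound 1 to compound 4 (0.07 log units; within the scatter) as a working figure only. For compound 4 the expected value is 12000 nM with an estimated range from 4000 nM to 35000 nM and a wide margin on both sides.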

Compound 4, half-maximal inhibitory concentration: > 100000 nM
Compound 4 was reported as a limit (the forecaster's own chance of this, stated with the estimate: 5%); at least 8.3-fold (0.92 log units) between middle value and limit.
By their numbers in this assay, from the lowest: compounds 1 and 3 (each within the scatter of the next); then compound 2. At a limit, above all of these: compound 4.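

In this assay, going by these compounds alone, hydrogen in place of butylamino on a double-bonded ring carbon gives an at least 7.1-fold higher number from compound 1 to compound 4 (0.85 log units; beyond the scatter), the first step at this position that lies beyond the scatter. The earlier step, no change at the digits printed from compound 1 to compound 3 (within the scatter), changed only the end of the chain and kept the amine nitrogen in place, so it could not show what compound 4 now shows: with the tert-butyl group retained, loss of the whole substituent does not leave the number where the two amine-bearing compounds stand. The value of compound 4, > 100000 nM, is a limit and not a number: the limit of > 100000 nM in this assay, at which 1 of the 4 values shown sits.

Still open, on these data alone, is whether the amine nitrogen or the chain attached to it accounts for the step, a question that an unsubstituted amine on the same ring carbon would help to separate from the results for butylamino and benzylamino. Also open, as far as these compounds go, is how an oxygen-linked chain such as butoxy would compare with butylamino at this position, and whether a longer chain on the nitrogen would stay level with compound 1 in this assay.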